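A few compounds are considered here, and "the series" means these few. Any claim that something is new, unique, unknown or untested is made for them only; others in the source may bear on it.

Measured so far:
Compound 1, `O=C(/C=C/c1ccccc1)c1ccc(NC(=O)c2ccccc2)cc1`, giving 36000 nM in a functional assay on HT-29 cells (Homo sapiens) for cytotoxicity, read by resazurin assay, with a stated time of 48 h; a higher number here means that more compound is needed for the effect, a lower number that less compound is needed.
Compound 2, `O=C(/C=C/c1cccc([N+](=O)[O-])c1)c1ccc(NC(=O)c2ccco2)cc1`, giving 3500 nM in this assay.

Compound 2 stands at the lower of the two numbers recorded in this assay. For the measured compounds named here, its only neighbour, compound 1, sits at a higher number, and the gap between the two lies beyond the usual scatter of such measurements. Going by the values given here, compound 1 and compound 2 differ in two places at once, so no single-change step is available from which the weight of either change could be read.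

Compound 3 `O=C(/C=C/c1cccc([N+](=O)[O-])c1)c1ccc(NC(=O)c2ccccc2)cc1` differs from compound 2 in one place only: phenyl in place of furan-2-yl on a carbonyl carbon. The rest of the structure is carried over unchanged. Among the compounds with values here, with no measured step of this kind to lean on, the expectation for compound 3 rests on the spread between compound 1 and compound 2 alone. Compound 3 is expected to give a number somewhat above that of compound 2, a step that may or may not exceed the scatter, a 2.3-fold higher number from compound 2 to compound 3 (0.36 log units; beyond the scatter). Compound 3 is therefore estimated at 8000 nM, with a range from 2500 nM to 25000 nM.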

Compound 3, half-maximal effective concentration: 3900 nM
The estimate for compound 3 lay 2.1-fold (0.31 log units) above the measured number; the range from low to high includes it.
By their numbers in this assay, from the lowest: compounds 2 and 3 (each within the scatter of the next); then compound 1.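

In this assay, for the compounds shown here, the exchange of furan-2-yl for phenyl on the carbonyl carbon bound to the amide-type nitrogen is the first single-change step at this position, and a 1.1-fold higher number from compound 2 to compound 3 (0.05 log units; within the scatter) shows that the two rings cannot be told apart here, although they differ in ring size and in the hetero atom. The second single change, nitro in place of hydrogen on an aromatic carbon, gives a 9.2-fold lower number from compound 1 to compound 3 (0.97 log units; beyond the scatter), so of the two changes that separate the compounds shown, only this one has a step beyond the scatter, though that step was read with phenyl on the carbonyl carbon. Nothing shown gives a measured reason for either result.

Going by these compounds alone, whether furan-2-yl and phenyl would also remain indistinguishable without the nitro group stays open, since the only comparison of these two rings carries it. On these data alone, it is equally open whether the tolerance on the carbonyl carbon extends beyond these two aromatic rings to an amine or a longer alkyl chain, and whether an amine or a carboxylic acid in place of the nitro group would give a step of similar size.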